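Hydroxamic Acid Tail Swap on a Shared Mdm2 Scaffold

The source may report more compounds than this note shows. Statements on the series, on what has been measured and on what is new or still open speak of the compounds shown alone.

Measured so far:
compound 1 `CCOc1cc(C(C)(C)C)ccc1C1=NC(c2ccc(Cl)cc2)C(c2ccc(Cl)cc2)N1C(=O)N1CCN(Cc2ccc(C(=O)NO)cc2)CC1`: 260 nM
compound 2 `CCOc1cc(C(C)(C)C)ccc1C1=NC(c2ccc(Cl)cc2)C(c2ccc(Cl)cc2)N1C(=O)NCCCCCCC(=O)Nc1ccccc1N`: 620 nM

In an assay on isolated protein for inhibition of E3 ubiquitin-protein ligase Mdm2 (Homo sapiens), read by fluorescence polarization, with a stated time of 30 min (on this read-out higher numbers stand for weaker inhibition and lower numbers for stronger inhibition), compound 1 gives 260 nM, the lowest of the two numbers; compound 2 gives 620 nM, a higher number beyond the scatter. Compound 3 `CCOc1cc(C(C)(C)C)ccc1C1=NC(c2ccc(Cl)cc2)C(c2ccc(Cl)cc2)N1C(=O)N1CCN(c2ncc(C(=O)NO)cn2)CC1` keeps the core of compound 1 and differs from it only in the group on an amine nitrogen in a ring: 5-(hydroxycarbamoyl)pyrimidin-2-yl in place of 4-(hydroxycarbamoyl)benzyl on an amine nitrogen in a ring. Going by the values given here, no measured pair shows a change of this kind, so the step of a 1.2-fold higher number from compound 1 to compound 3 (0.06 log units; within the scatter) is expected to stay within the scatter, in no firm direction. Compound 3 is therefore estimated at 300 nM, with a range from 100 nM to 900 nM.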

Compound 3, inhibition constant: 1050 nM
Beside the measured number, compound 3's estimate is 3.5-fold (0.54 log units) below it; measured number above the stated range.
By their numbers in this assay, from the lowest: compound 1; then compounds 2 and 3 (each within the scatter of the next).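

In this assay, the group on the amine nitrogen in the ring matters: 5-(hydroxycarbamoyl)pyrimidin-2-yl in place of 4-(hydroxycarbamoyl)benzyl gives a 4.0-fold higher number from compound 1 to compound 3 (0.61 log units; beyond the scatter). Both groups carry the hydroxycarbamoyl unit, so that unit alone does not set the number at this position. Nothing available explains this step. The compounds shown leave open whether the step follows from the ring nitrogens or from the missing methylene of the benzyl group, as the change alters both at once. As far as these compounds go, how a 4-(hydroxycarbamoyl)phenyl group on that nitrogen would read also remains open.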